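The compounds below may be only part of what the source reports. "The series", "measured", "known", "first", "only" and "open" are said of these compounds alone.

Compound 1 `Cn1ncc(Cl)c1-c1cc(C(=O)N[C@@H]2CN[C@H](CCCO)C[C@H]2c2ccc(Cl)c(Cl)c2)oc1Cl`: 510 nM
Compound 2 `Cn1ncc(Cl)c1-c1cc(C(=O)N[C@@H]2CNCC[C@H]2c2ccc(C(F)(F)F)cc2)oc1Cl`: 280 nM
Compound 3 `O=C(N[C@@H]1CNCC[C@H]1c1ccc(Cl)cc1)c1ccc(-c2ncnc3c2CCC3O)s1`: 23000 nM

In a functional assay on HCT-116 cells (Homo sapiens) for antiproliferative activity, read by sulforhodamine B assay, with a stated time of 72 h (a lower number here means a stronger inhibitor, a higher number a weaker inhibitor), compound 1 gives 510 nM, the second highest of the three numbers. Its nearest neighbour is compound 2, whose value of 280 nM lies within the scatter of that of compound 1, so no order can be drawn between the two. Compound 3, built on a different core, is far weaker at 23000 nM, a gap that lies well beyond the scatter. Compound 4 `Cn1ncc(Cl)c1-c1cc(C(=O)N[C@@H]2CN[C@H](CC(=O)NCCO)C[C@H]2c2ccc(Cl)c(Cl)c2)oc1Cl` has not yet been measured. It keeps the core of compound 1 and differs from it in one place: (2-hydroxyethyl)carbamoyl in place of 2-hydroxyethyl on a saturated chain carbon bound to a saturated ring carbon. Among the measured compounds shown here, no step of this kind between measured compounds is available, so the expectation rests on compound 1 alone. For compound 4 the expected step is a 1.4-fold higher number from compound 1 to compound 4 (0.14 log units; within the scatter), modest and towards a higher number, perhaps not beyond the scatter. Compound 4 is therefore estimated at 700 nM, with a range from 250 nM to 2000 nM.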

Compound 4, half-maximal inhibitory concentration: 670 nM
Beside the measured number, compound 4's estimate is 1.0-fold (0.02 log units) above it; the measured number falls inside the stated range.
By their numbers in this assay, from the lowest: compounds 2, 1 and 4 (each within the scatter of the next, the first and the last beyond it); then compound 3.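

In this assay, replacing 2-hydroxyethyl with (2-hydroxyethyl)carbamoyl on a saturated chain carbon bound to a saturated ring carbon gives a 1.3-fold higher number from compound 1 to compound 4 (0.12 log units; within the scatter), the only step shown that isolates a change at this position. Among the compounds shown here, the chain can thus carry the larger group, with its carbonyl and amide hydrogen, without a change that stands clear of the scatter, whereas the earlier compounds offered no one-place comparison at all. No measurement offered here explains why the number holds.

Going by these compounds, what a carboxylic acid or an amine at the end of this chain would do remains open, as does whether a longer chain would stay within the same range. Also open is what the chain itself contributes, since no compound shown differs from compound 1 solely by lacking it.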